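Swapping Amino for Methoxycarbonyl: What to Expect

The source may report more compounds than this note shows. Statements on the series, on what has been measured and on what is new or still open speak of the compounds shown alone.

The measured compounds:
Compound 1, `N#Cc1cc(=O)[nH]c(=O)n1[C@@H]1O[C@H](CO)[C@@H](O)[C@H]1O`, gives in a functional assay on ML1 cells (Homo sapiens) for antiproliferative activity, read by WST assay, with a stated time of 3 days (on this read-out higher numbers stand for weaker inhibition and lower numbers for stronger inhibition), a value that is only a limit of the assay, > 50000 nM.
Compound 2, `O=c1cc(I)n([C@@H]2O[C@H](CO)[C@@H](O)[C@H]2O)c(=O)[nH]1`, gives in this assay a value of 15300 nM.
Compound 3, `Nc1cc(=O)[nH]c(=O)n1[C@@H]1O[C@H](CO)[C@@H](O)[C@H]1O`, gives in this assay only a limit, > 50000 nM.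

Compound 3 therefore stands without a real number; its value is one of the two that sit at the limit described by the limit of > 50000 nM in this assay, at which 2 of the 3 values shown sit. Compound 4, `COC(=O)c1cc(=O)[nH]c(=O)n1[C@@H]1O[C@H](CO)[C@@H](O)[C@H]1O`, differs from compound 3 in a single place: methoxycarbonyl in place of amino on an aromatic carbon.

Of the measured steps, an at least 3.2-fold higher number from compound 2 to compound 3 (0.51 log units; beyond the scatter) is the only readable one: replacing iodo with amino pushed the value from a measurable number to the limit. The step that the two limits leave unreadable from compound 1 to compound 3 cannot be read, both of its ends being limits. For the measured compounds named here, neither step involves methoxycarbonyl, and the only compound carrying a different carbon-based group, compound 1 with cyano, also sits at the limit. Compound 4 is therefore expected to stay close to where compound 3 stands: in this assay compound 4 is estimated at 40000 nM, within 10000 nM to 150000 nM. The expected step of an at least 1.2-fold lower number from compound 3 to compound 4 (0.09 log units; that floor lies within the scatter) is small and uncertain, with a good chance that only a limit is reported again.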

Compound 4, half-maximal inhibitory concentration: > 50000 nM
Compound 4 gave a limit, no number (the forecaster's own chance of this, stated with the estimate: 60%); middle value at least 1.2-fold (0.09 log units) from the limit.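

In this assay, going from iodo to methoxycarbonyl gives an at least 3.2-fold higher number from compound 2 to compound 4 (0.51 log units; beyond the scatter), so compound 2 is now set apart from three compounds with other groups at this position. Amino, with its hydrogen-bond donor, and the larger methoxycarbonyl, with no donor but two acceptors, do not differ in any readable way, so this swap did not bring out a measurable number. The steps among compound 1, compound 3 and compound 4 cannot be read and these three cannot be ranked, as all that can be said is that they share one limit, which is a limit and not a number: the limit of > 50000 nM in this assay, at which 3 of the 4 values shown sit.

As far as these compounds go, whether a measurable value belongs to iodo alone, or also appears with bromo, chloro or a methyl group at this position, stays open. Also open, from the compounds shown here alone, are how far compound 1, compound 3 and compound 4 truly lie from one another, and whether a carboxylic acid or a primary amide in the same place would give a real number.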